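Arylsulfonyl Piperazines as Lysophosphatidic Acid Receptor 2 Antagonists

A few compounds are considered here, and "the series" means these few. Any claim that something is new, unique, unknown or untested is made for them only; others in the source may bear on it.

Compound 1 `Cc1csc2c(N[C@@H](C)CN3CCN(S(=O)(=O)Cc4ccccc4)CC3)ncnc12`: 1860 nM
Compound 2 `Cc1ccccc1N1CCN(C[C@H](C)Nc2nc(C(F)(F)F)nc3ccccc23)CC1`: 730 nM
Compound 3 `Cc1noc(-c2ccccc2)c1NC(=O)OC(C)c1ccccc1`: > 50000 nM

In a functional assay on RH7777 cells for antagonist activity at lysophosphatidic acid receptor 2 (Homo sapiens), read by calcium flux (on this read-out higher numbers stand for weaker inhibition and lower numbers for stronger inhibition), compound 1 gives 1860 nM, the higher of the two numbers in hand; compound 2 gives 730 nM, a gap beyond the scatter. For compound 3 the value of > 50000 nM is a limit of this assay (the limit of > 50000 nM in this assay, at which 1 of the 3 values shown sits), not a number. Compound 4 `Cc1csc2c(N[C@@H](C)CN3CCN(S(=O)(=O)c4cccc(Cl)c4)CC3)ncnc12` differs from compound 1 by a single exchange: 3-chlorophenyl in place of benzyl on a sulfonyl sulfur. Going by the values given here, no measured pair shows such a change, so there is no direct guide to its size or direction. The step expected in this assay a 1.2-fold lower number from compound 1 to compound 4 (0.09 log units; within the scatter) is therefore taken as no larger than the scatter. Compound 4 is estimated at 1500 nM, with a range from 500 nM to 5000 nM.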

Compound 4, half-maximal inhibitory concentration: 35 nM
The estimate for compound 4 lay 43-fold (1.63 log units) above the measured number; measured number below the stated range.
By their numbers in this assay, from the lowest: compound 4; then compound 2; then compound 1. At a limit, above all of these: compound 3.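

In this assay, the substituent on the sulfonyl sulfur proves to be a sensitive position: 3-chlorophenyl in place of benzyl gives a 53-fold lower number from compound 1 to compound 4 (1.73 log units; beyond the scatter), although both groups have the same count of heavy atoms and one six-membered aromatic ring. Going by these compounds alone, the earlier compounds offered no pair differing in one place, so this is the first single change that can be read. No measurement shown accounts for the size of this step.

On these data alone, it remains open whether the chlorine or the removal of the benzyl methylene carries the step, and how an unsubstituted phenyl, or a methoxy group or an amine on the ring, would read.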